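A few compounds are considered here, and "the series" means these few. Any claim that something is new, unique, unknown or untested is made for them only; others in the source may bear on it.

Of the compounds shown here, two built on the same core have been tested so far in a functional assay (ileum) for inhibition, with Cavia porcellus as the target; a lower number here means a stronger inhibitor, a higher number a weaker inhibitor. The small parent, compound 1 `Cc1c(C)c2c(c(C)c1O)SCO2`, gives 2400 nM, a real number. Compound 2 `CCCCCCCC1Oc2c(C)c(C)c(O)c(C)c2S1`, which carries a long chain, reads > 33900 nM. That value is a limit of the assay and not a number, so compound 2 has no exact position on the scale.

The next compound changes that chain. Compound 3 `Cc1c(C)c2c(c(C)c1O)SC(CCC(=O)O)O2` has carboxy in place of pentyl, on a saturated chain carbon, two bonds along the chain from a saturated ring carbon: carboxy in place of pentyl on a saturated chain carbon, two bonds along the chain from a saturated ring carbon. The same difference can also be read as hexyl to carboxymethyl.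

Within the data shown here, no measured pair shows what such a swap does, so any forecast here is loose. Among the measured compounds shown here, the only firm number to lean on is that of compound 1 at 2400 nM. A modest move toward lower numbers is expected, with an estimated step of an at least 2.2-fold lower number from compound 2 to compound 3 (0.35 log units; beyond the scatter), and compound 3 may well end up at a limit again. For compound 3 the expected value is 15000 nM, with an estimated range of 3000 nM to 60000 nM.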

Compound 3, half-maximal inhibitory concentration: > 37200 nM
Compound 3: no number, only a limit; the forecaster's own chance of this, stated with the estimate: 35%; middle value at least 2.4-fold (0.39 log units) away from the limit.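

In this assay compound 3 reads > 37200 nM as a limit of the assay and not a number. Even so, the comparison with the small parent is clear: 2-carboxyethyl in place of hydrogen on a saturated ring carbon gives an at least 15-fold higher number from compound 1 to compound 3 (1.19 log units; beyond the scatter) and so weakens inhibition well beyond the usual scatter, which shows that this ring carbon does not accept this acid-bearing chain without a large loss. The swap of pentyl for carboxy cannot be read, so the long chain of compound 2 and the carboxy-ended chain of compound 3 cannot be ranked against each other, as each of them gives only a limit: the limit of > 33900 nM in this assay, at which 1 of the 3 values shown sits.

From the compounds shown here alone, it remains open how much of the loss comes from the length of the chain and how much from the group at its end, and how far above the limit either compound lies. A single methyl on the same ring carbon, or an amine at the end of the chain in place of the carboxylic acid, would be needed to tell whether any substituent here can keep the level of compound 1 at 2400 nM in this assay.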